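A few compounds are considered here, and "the series" means these few. Any claim that something is new, unique, unknown or untested is made for them only; others in the source may bear on it.

Compound 1 `CCOC(=O)Nc1cccc2c1CN(C)CC2c1ccccc1` is the starting point. Among the measured compounds shown here, in a functional assay on the whole organism for inhibition of sodium-dependent dopamine transporter (Mus musculus) (a higher number here means that more compound is needed for the effect, a lower number that less compound is needed), compound 1 gives 2.5 mg/kg, the lowest of the two numbers measured so far. The other measured compound is compound 2 `CCOC(=O)Nc1cccc2c1CN(C)CC2c1ccc(Cl)cc1`, which in this assay gives 21 mg/kg; the step of an 8.4-fold higher number from compound 1 to compound 2 (0.92 log units; beyond the scatter) came with chloro in place of hydrogen on an aromatic carbon. Compound 3 `CCCCNCC(=O)Nc1cccc2c1CN(C)CC2c1ccccc1` is not yet measured. It differs from compound 1 by (butylamino)methyl in place of ethoxy on a carbonyl carbon. For the measured compounds named here, the only measured step concerns an aromatic carbon elsewhere in the shared core, not the carbonyl carbon changed here, so no measured step bears directly on this change and the direction is open. With nothing to point either way, compound 3 is expected to stay close to compound 1, giving an estimated step of a 2.0-fold higher number from compound 1 to compound 3 (0.30 log units; within the scatter), with a wide range allowed. The estimate for compound 3 is 5 mg/kg, expected between 1.5 mg/kg and 25 mg/kg.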

Compound 3, dose for half-maximal effect: 25 mg/kg
Beside the measured number, compound 3's estimate is 5.0-fold (0.70 log units) below it; low and high end bracket the measured number.
By their numbers in this assay, from the lowest: compound 1; then compounds 2 and 3 (each within the scatter of the next).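

In this assay, putting (butylamino)methyl in place of ethoxy on the carbonyl carbon gives a 10-fold higher number from compound 1 to compound 3 (1.00 log units; beyond the scatter), so this position is not indifferent to the group it carries. The swap changes several things at once: 3 heavy atoms give way to 6, the oxygen of ethoxy is gone, and a nitrogen with 1 hydrogen-bond donor enters, so this one step cannot show which of these differences matters. Nothing measured here explains the step.

Still open, from the compounds shown here alone, is whether a smaller group on the same carbonyl carbon, such as methoxy or (methylamino)methyl, would stay closer to compound 1. Also open, going by these compounds, is whether the nitrogen or the butyl chain counts for more, which a plain pentyl chain in place of (butylamino)methyl could help separate.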